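This account rests on a few compounds, and the source may have more. Where it says the series, first, only, none or still open, it means among the compounds named here.

In an ADME assay on L929 cells (Mus musculus, culture collection number NCTC 929) for cytotoxicity, read by MTT assay, with a stated time of 72 h (on this read-out lower numbers stand for stronger inhibition and higher numbers for weaker inhibition), compound 1 `CCCCCCCCc1c(O)cc(C)oc1=O` gives 145000 nM. Compound 3 `Cc1cc(O)c(C(=O)CCC2CCCCC2)c(=O)o1` gives 117000 nM, and these two numbers lie within the usual scatter of each other, so neither compound can be called the stronger. Compound 2 `Cc1cc(O)c(CC2CCCCC2)c(=O)o1` is reported only as a limit, > 200000 nM. Compound 1 therefore stands level with compound 3, and the data offer only these two numbers for comparison.

Compound 4 `CCCCCCCCCCCCc1c(O)cc(C)oc1=O` keeps the core of compound 1 and changes only the chain: butyl in place of hydrogen on a saturated chain carbon, eight bonds along the chain from an aromatic carbon. Within the data shown here, no measured pair of compounds differs in one place only, so this expectation rests on little. A modest move towards a lower number in this assay seems the likeliest outcome, although no change beyond the scatter remains possible. The estimated change is a 2.1-fold lower number from compound 1 to compound 4 (0.32 log units; beyond the scatter). For compound 4 the expected value is 70000 nM, with an estimated range from 20000 nM to 200000 nM.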

Compound 4, half-maximal inhibitory concentration: 57200 nM
Compound 4: the middle estimate sits 1.2-fold (0.09 log units) above what was measured; the measured number falls inside the stated range.
By their numbers in this assay, from the lowest: compound 4; then compounds 3 and 1 (each within the scatter of the next). At a limit, above all of these: compound 2.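

In this assay, butyl in place of hydrogen on a saturated chain carbon, eight bonds along the chain from an aromatic carbon, gives a 2.5-fold lower number from compound 1 to compound 4 (0.40 log units; beyond the scatter). This is the first change at a single place among these compounds, and it shows that this place on the chain can shift the number beyond the usual scatter, though only modestly, while the core stays the same. Compound 2 is reported as a limit and not a number, and it adds no such step: the limit of > 200000 nM in this assay, at which 1 of the 4 values shown sits.

A single step sets no trend along the chain. From the compounds shown here alone, whether a still longer chain would lower the number further remains open, as does what an amine or a carboxylic acid at this same place would do.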